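Stability of compound 1 and a new ring swap

The source may report more compounds than this note shows. Statements on the series, on what has been measured and on what is new or still open speak of the compounds shown alone.

Measured in an ADME assay on microsomes from liver (Mus musculus) for metabolic stability, read by LC-MS, with a stated time of 10 min; on this read-out lower numbers stand for a less stable compound and higher numbers for a more stable compound:
- compound 1 `c1cnc2c(c1)CCC[C@@H]2N(CC1CC1)C[C@H]1Cc2c(cccc2N2CCNCC2)CN1` gives 88.3%
- compound 2 `C[C@@H]1CN(c2cccc3c2C[C@H](CN(C)[C@H]2CCCc4cccnc42)NC3)C[C@H](C)N1` gives 85.6%
- compound 3 `CC(C)N1CCN(c2cccc3c2C[C@H](CN(C)[C@H]2CCCc4cccnc42)NC3)CC1` gives 15.1%

Compound 1 and compound 2 lie within the scatter of each other, and both stand far above compound 3 . The next structure, compound 4 `FC1(F)CCC(CN(C[C@H]2Cc3c(cccc3N3CCNCC3)CN2)[C@H]2CCCc3cccnc32)CC1`, carries 4,4-difluorocyclohexyl in place of cyclopropyl on a saturated chain carbon bound to an amine nitrogen.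

For the measured compounds named here, no measured step touches that place. Going by the values given here, the only step available is a number 70.5 percentage points lower from compound 2 to compound 3 (beyond the scatter), which comes from 4-isopropylpiperazin-1-yl replacing 3,5-dimethylpiperazin-1-yl on an aromatic carbon. It shows that a single swap can move this assay a long way, but not how far this swap will move it. Compound 1 at 88.3% has little room to rise, so a fall of moderate size is the more likely outcome, though a result within the scatter remains possible.

The expected change is a number 23.3 percentage points lower from compound 1 to compound 4 (beyond the scatter). For compound 4 the estimate is 65%, with an expected range from 35% to 90%.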

Compound 4, percent of the compound remaining: 76.6%
Beside the measured number, compound 4's estimate is 11.6 percentage points below it, within the range that was stated.
By their numbers in this assay, from the lowest: compound 3; then compounds 4, 2 and 1 (each within the scatter of the next, the first and the last beyond it).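

In this assay, for the compounds shown here, this is the first measured change at the saturated chain carbon bound to an amine nitrogen, and 4,4-difluorocyclohexyl in place of cyclopropyl gives a number 11.7 percentage points lower from compound 1 to compound 4 (beyond the scatter). The entering group has 8 heavy atoms and the leaving group 3, so this place accepts a much larger ring at a modest cost, with compound 4 still at 76.6%. Nothing available here explains why the number fell, or whether the larger ring or the two fluorine atoms account for the step.

From the compounds shown here alone, what a plain cyclohexyl ring without fluorine would give at this place remains open, and a comparison with it could separate the ring from the fluorine atoms. Open too, going by these compounds, is how an open chain such as isobutyl would fare at this place.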